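Swapping a Methoxyphenyl for a Dichlorophenyl Amide Substituent

A few compounds are considered here, and "the series" means these few. Any claim that something is new, unique, unknown or untested is made for them only; others in the source may bear on it.

Three amides sharing a common core have been measured in an assay on brain for inhibition of Fatty-acid amide hydrolase 1 (Rattus norvegicus), read by scintillation counting, with a stated time of 10 min; on this read-out lower numbers stand for stronger inhibition and higher numbers for weaker inhibition. Compound 1 `CC(C)Cc1ccc(C(C)C(=O)NCc2ccc(C(F)(F)F)cc2)cc1` gives 51000 nM in this assay. Compound 2 `COc1ccccc1CNC(=O)C(C)c1ccc(CC(C)C)cc1` gives 18000 nM. Compound 3 `COc1ccc(CNC(=O)C(C)c2ccc(CC(C)C)cc2)cc1O` gives 18000 nM. On these numbers compound 2 sits level with compound 3, and the two together hold the lowest numbers of the three; compound 1 stands apart from them with a higher number that lies beyond the usual scatter of repeated measurements.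

The next compound, compound 4 `CC(C)Cc1ccc(C(C)C(=O)NCc2cc(Cl)ccc2Cl)cc1`, has not yet been tested in this assay. It differs from compound 2 in one place: 2,5-dichlorophenyl in place of 2-methoxyphenyl on a saturated chain carbon bound to an amide-type nitrogen. Among the compounds with values here, no pair of measured compounds shows what this particular exchange does, so the expectation rests only on the spread of the three numbers already seen. Since every measured compound falls in a modest band, a step of moderate size is expected, and the direction is uncertain; the estimated step from compound 2 to compound 4 is a 1.4-fold higher number from compound 2 to compound 4 (0.14 log units; within the scatter). For compound 4 the expected value in this assay is 25000 nM, with a range from 8000 nM to 80000 nM.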

Compound 4, half-maximal inhibitory concentration: 4400 nM
Beside the measured number, compound 4's estimate is 5.7-fold (0.75 log units) above it; the whole stated range lies above it.
By their numbers in this assay, from the lowest: compound 4; then compounds 2 and 3 (each within the scatter of the next); then compound 1.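

In this assay, within the data shown here, putting 2,5-dichlorophenyl in place of 2-methoxyphenyl on the saturated chain carbon bound to the amide-type nitrogen gives a 4.1-fold lower number from compound 2 to compound 4 (0.61 log units; beyond the scatter) and this is the first step that can be read between two measured compounds. It shows that the group at this position can move the number beyond the scatter, even though the entering and leaving groups have the same count of heavy atoms and each holds one six-membered aromatic ring. Nothing measured here says why the number falls.

Still open, going by these compounds, is whether both chlorines are needed or a phenyl with a single chlorine would give a similar number. Also open, on these data alone, is how a phenyl carrying a nitrile or an amine would compare at this position.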